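Working notes: hydrogen in place of chloro

The compounds below may be only part of what the source reports. "The series", "measured", "known", "first", "only" and "open" are said of these compounds alone.

Three compounds carry measurements in a functional assay on PC-3 cells (Homo sapiens) for inhibition, read by sulforhodamine B assay, with a stated time of 48 h; a lower number here means a stronger inhibitor, a higher number a weaker inhibitor. Compound 1 `Cc1ccc2occ(C3N=C(c4ccccc4)SS3)c(=O)c2c1` returns > 100000 nM, which is a limit of the assay and not a number. Compound 2 `O=c1c(C2N=C(c3ccccc3)SS2)coc2ccc(F)cc12` likewise returns the limit > 100000 nM. The step that the two limits leave unreadable from compound 1 to compound 2 therefore cannot be sized. Going by the values given here, compound 3 `O=c1c(C2N=C(c3ccccc3)SS2)coc2cc(Cl)ccc12` gives 38400 nM in this assay, the only number among the three. The remaining two values are limits, as the limit of > 100000 nM in this assay, at which 2 of the 3 values shown sit, records. Among the compounds with values here, compound 3 therefore stands alone as the one compound with a readable potency.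

Compound 4 `O=c1c(C2N=C(c3ccccc3)SS2)coc2ccccc12` differs from compound 3 by hydrogen in place of chloro on an aromatic carbon. Within the data shown here, no measured step bears on this change: the single step recorded, from compound 1 to compound 2, is unreadable between two limits, and no measured pair differs by loss of the chloro alone. Among the measured compounds shown here, what the values do show is that compound 3, which carries the chloro, is the one compound with a number, while the compounds carrying methyl or fluoro sit at the limit. On that basis a weakening step is expected in this assay, a 2.3-fold higher number from compound 3 to compound 4 (0.37 log units; beyond the scatter), with a substantial chance that only a limit is reported. Compound 4 is estimated at 90000 nM, in the range 30000 nM to 300000 nM.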

Compound 4, half-maximal inhibitory concentration: > 100000 nM
Compound 4 gave a limit, no number; the forecaster's own chance of this, stated with the estimate: 50%; at least 1.1-fold (0.04 log units) between middle value and limit.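

In this assay, going by these compounds alone, the chloro gives the first readable step: an at least 2.6-fold higher number from compound 3 to compound 4 (0.41 log units; beyond the scatter). Within the data shown here, the size of this step is a lower bound, since one end of it is a limit, yet it ties the only number among the four compounds to the chloro on this aromatic carbon, meta to a fused ring and para to a fused ring, as the shared core with hydrogen there does not return a number. The steps among compound 1, compound 2 and compound 4 cannot be read, and the series now rests mostly on one ceiling value: the limit of > 100000 nM in this assay, at which 3 of the 4 values shown sit.

Left open is whether bromo, methoxy or an amine on this same carbon would keep a number in this assay, and whether methyl or fluoro would do so there, given that only the chloro has been seen at this carbon. Also open, as far as these compounds go, is how far beyond its limit compound 4 lies, and therefore the true size of the loss on going from chloro to hydrogen.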